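Working notes: from compound 2 to compound 3

The compounds below may be only part of what the source reports. "The series", "measured", "known", "first", "only" and "open" are said of these compounds alone.

Series so far in a physicochemical assay for lipophilicity, read by HPLC, in phosphate buffer, measured as octanol-water partition, at pH 7.4, tested at 100 uM (a lower number here means a more polar compound, a higher number a more lipophilic compound), with two measured compounds
- compound 1 `Cc1ccccc1-c1cccc(CNc2ccc(OCC(=O)O)c(F)c2)c1` gives 2.41
- compound 2 `Cc1cc(OCCO)ccc1-c1cccc(CNc2ccc(OCC(=O)O)c(F)c2)c1` gives 1.65

Compound 2 stands lowest of the two numbers at 1.65 and lies beyond the scatter from compound 1. The change to compound 3 `Cc1cc(OCCCS(C)(=O)=O)ccc1-c1cccc(CNc2ccc(OCC(=O)O)c(F)c2)c1` is (methylsulfonyl)methyl in place of hydroxy on a saturated chain carbon, two bonds along the chain from an oxygen on an aromatic ring and turns 2-hydroxyethoxy into 3-(methylsulfonyl)propoxy.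

Among the measured compounds shown here, only one measured step bears on this, and only indirectly. The step of a number 0.76 log units lower from compound 1 to compound 2 (beyond the scatter) is modest and beyond the scatter, and it came with 2-hydroxyethoxy in place of hydrogen on an aromatic carbon. For the measured compounds named here, no measured pair has (methylsulfonyl)methyl in place of hydroxy, so the data give no direct size for this change. A smaller shift than the step of a number 0.76 log units lower from compound 1 to compound 2 (beyond the scatter) is therefore expected, slightly upward if anything, with the direction left open. The estimated step of a number 0.10 log units higher from compound 2 to compound 3 (within the scatter) is expected to stay within the scatter. In this assay the expected value for compound 3 is 1.75 with a range from 1.35 to 2.15 as the estimate.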

Compound 3, distribution coefficient: 1.59
Compound 3: the middle estimate sits 0.16 log units above what was measured; the range from low to high includes it.
By their numbers in this assay, from the lowest: compounds 3 and 2 (each within the scatter of the next); then compound 1.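

In this assay, hydroxy gives way to (methylsulfonyl)methyl on a saturated chain carbon, two bonds along the chain from an oxygen on an aromatic ring, with a number 0.06 log units lower from compound 2 to compound 3 (within the scatter) as the result. At this place, then, a larger group without a hydrogen-bond donor takes the place of hydroxy, and compounds 2 and 3 cannot be told apart in this measurement. Against compound 1, the 3-(methylsulfonyl)propoxy chain gives a number 0.82 log units lower from compound 1 to compound 3 (beyond the scatter) and so stays beyond the scatter, as the 2-hydroxyethoxy chain does with a number 0.76 log units lower from compound 1 to compound 2 (beyond the scatter) on the same aromatic carbon; no measured property accounts for this result.

Compound 3 differs from compound 2 in both chain length and chain end, so the two contributions remain unseparated, and a 3-hydroxypropoxy or 2-(methylsulfonyl)ethoxy group would pull them apart. Also open, as far as these compounds go, is whether this level in this assay holds for a chain ending in an amine or a carboxylic acid, or for a longer chain, at the same place.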